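Triazole Aryl Swap on a Terpenoid Ester: Methyl to Bromo

A few compounds are considered here, and "the series" means these few. Any claim that something is new, unique, unknown or untested is made for them only; others in the source may bear on it.

Compound 1 `C/C(=C\CC/C(C)=C/CC[C@@H]1[C@@]2(C)CCC(=O)C(C)(C)[C@H]2CC[C@@]1(C)O)CC/C=C(\C)C(=O)OCc1cn(-c2ccccc2C)nn1` gives in a functional assay on A549 cells (Homo sapiens) for antiproliferative activity, read by MTT assay, with a stated time of 48 h (a lower number here means a stronger inhibitor, a higher number a weaker inhibitor), only the limit > 150000 nM.
Compound 2 `C/C(=C\CC/C(C)=C/CC[C@@H]1[C@@]2(C)CCC(=O)C(C)(C)[C@H]2CC[C@@]1(C)O)CC/C=C(\C)C(=O)OCc1cn(-c2ccccc2Br)nn1` gives in this assay only the limit > 150000 nM.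
Compound 3 `C/C(=C\CC/C(C)=C/CC[C@@H]1[C@@]2(C)CCC(=O)C(C)(C)[C@H]2CC[C@@]1(C)O)CC/C=C(\C)C(=O)OCc1cn(-c2cccc(C)c2)nn1` gives in this assay only the limit > 150000 nM.

Compound 3 therefore stands where every measured compound stands: at a limit of the assay, not at a number, as the limit of > 150000 nM in this assay, at which 3 of the 3 values shown sit, records. The three steps among the measured compounds, a step that the two limits leave unreadable from compound 1 to compound 2, a step that the two limits leave unreadable from compound 1 to compound 3 and a step that the two limits leave unreadable from compound 2 to compound 3, cannot be sized for the same reason.

Compound 4 `C/C(=C\CC/C(C)=C/CC[C@@H]1[C@@]2(C)CCC(=O)C(C)(C)[C@H]2CC[C@@]1(C)O)CC/C=C(\C)C(=O)OCc1cn(-c2cccc(Br)c2)nn1` differs from compound 3 by bromo in place of methyl on an aromatic carbon. Among the measured compounds shown here, the closest measured step is the one from compound 1 to compound 2, where the same exchange on the aromatic ring left both compounds at the limit. Nothing in the measured data shows any exchange on that ring moving a compound into the readable range. Compound 4 is therefore expected to give a step that the limit leaves unreadable from compound 3 to compound 4 in this assay, most likely again a limit, with an estimate of 250000 nM and a range from 100000 nM to 600000 nM.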

Compound 4, half-maximal inhibitory concentration: > 150000 nM
Compound 4 gave a limit, no number; the forecaster's own chance of this, stated with the estimate: 85%; the middle value does not contradict the limit.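

In this assay compound 4 gives > 150000 nM as a limit and not a number, so its steps to compound 1, compound 2 and compound 3 cannot be read: the limit of > 150000 nM in this assay, at which 4 of the 4 values shown sit. The compounds shown leave open whether in this assay any other aryl group on the triazole would give a number at all.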